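A few compounds are considered here, and "the series" means these few. Any claim that something is new, unique, unknown or untested is made for them only; others in the source may bear on it.

Measured so far in a functional assay on CCRF-CEM/VCR-1000 cells (Homo sapiens) for inhibition; on this read-out lower numbers stand for stronger inhibition and higher numbers for weaker inhibition:
compound 1 `CC(=O)c1ccc(OCC(O)CN2CCCCC2)cc1`, 75900 nM
compound 2 `O=C(CCc1ccccc1)c1cccc(OCC(O)CN2CCN(c3ccc(F)cc3)CC2)c1`, 1120 nM
compound 3 `COC(CCc1ccccc1)c1ccccc1OCC(O)CN(C(C)C)C(C)C`, 660 nM

Compound 2 holds the second-highest number of the three. Compound 3 sits within the scatter of compound 2, so no order between them is drawn; compound 1 lies far above compound 2, a gap beyond the scatter. Compound 4 `CC(=O)c1cccc(OCC(O)CN2CCN(c3ccc(F)cc3)CC2)c1` is not yet measured. Against compound 2 it carries hydrogen in place of benzyl on a saturated chain carbon bound to a carbonyl carbon, that is phenethylcarbonyl to acetyl. Going by the values given here, no pair of measured compounds isolates this change; compound 1 also carries acetyl but differs from compound 2 in further places, so its higher number cannot be tied to acetyl alone. A step toward weaker inhibition, beyond the scatter, is expected. For compound 4 the estimate is 5000 nM, ranging from 1500 nM to 20000 nM. This means an expected step of a 4.5-fold higher number from compound 2 to compound 4 (0.65 log units; beyond the scatter).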

Compound 4, half-maximal inhibitory concentration: 11400 nM
For compound 4 the middle estimate is 2.3-fold (0.36 log units) below the measured one; the measured number falls inside the stated range.
By their numbers in this assay, from the lowest: compounds 3 and 2 (each within the scatter of the next); then compound 4; then compound 1.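

Going by these compounds alone, replacing phenethylcarbonyl with acetyl gives a 10-fold higher number from compound 2 to compound 4 (1.01 log units; beyond the scatter) in this assay and is the first change that can be read in isolation. With the rest of the structure held constant, this large step belongs to the loss of benzyl from the saturated chain carbon bound to the carbonyl carbon. No measurement explains its size.

As far as these compounds go, it remains open whether the step follows the aromatic ring or the chain length. A propyl or pentyl chain in place of phenethyl would help separate the two.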